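A few compounds are considered here, and "the series" means these few. Any claim that something is new, unique, unknown or untested is made for them only; others in the source may bear on it.

In a functional assay on HeLa cells (Homo sapiens) for antiproliferative activity, read by MTT assay, with a stated time of 72 h (a higher number here means a weaker inhibitor, a lower number a stronger inhibitor), compound 3 (`C/C=C/C(=O)Nc1cccc(Oc2nc(Nc3ccc(OC)nc3)nc3c2CSCC3)c1`) gives 16500 nM. Compound 1 (`CCC/C=C/C(=O)Nc1cccc(Oc2nc(Nc3ccc(OC)cc3)nc3c2CSCC3)c1`) gives 12800 nM and compound 2 (`C=CC(=O)Nc1cccc(Oc2nc(Nc3ccc(OC)nc3)nc3c2CSCC3)c1`) gives 26300 nM. Compound 3 lies within the scatter of each of them, so no order can be read between it and either one.

Compound 4 (`CCC/C=C/C(=O)Nc1cccc(Oc2nc(Nc3ccc(OC)nc3)nc3c2CSCC3)c1`) keeps the core of compound 3 and alters only the chain on the carbonyl: ethyl in place of hydrogen on a saturated chain carbon bound to a double-bonded chain carbon. This turns the (prop-1-en-1-yl)carbonyl into (pent-1-en-1-yl)carbonyl.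

For the measured compounds named here, one measured step bears directly on this chain: a 1.6-fold lower number from compound 2 to compound 3 (0.20 log units; within the scatter), with prop-1-en-1-yl in place of vinyl on a carbonyl carbon. Compound 1 already carries the (pent-1-en-1-yl)carbonyl on a different core, and its value of 12800 nM gives only indirect support. Going by the values given here, no measured pair isolates the longer chain itself.

No shift beyond the scatter is therefore expected in this assay, and the estimated change is a 1.2-fold lower number from compound 3 to compound 4 (0.07 log units; within the scatter). Compound 4 is estimated at 14000 nM, with an expected range of 7000 nM to 28000 nM.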

Compound 4, half-maximal inhibitory concentration: 15300 nM
The estimate for compound 4 lay 1.1-fold (0.04 log units) below the measured number, within the range that was stated.
By their numbers in this assay, from the lowest: compounds 1, 4, 3 and 2 (each within the scatter of the next, the first and the last beyond it).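

Lengthening the chain on this carbonyl is now isolated in a measured pair, and in this assay the pair reads (a 1.1-fold lower number from compound 3 to compound 4 (0.03 log units; within the scatter)), so this position tolerates ethyl in place of hydrogen with no readable shift. Measured against the vinyl end of the series the result is the same (a 1.7-fold lower number from compound 2 to compound 4 (0.24 log units; within the scatter)), so vinyl and pent-1-en-1-yl cannot be told apart on this core. For the compounds shown here, the pent-1-en-1-yl chain also allows the first direct reading of the ring on the nitrogen (a 1.2-fold higher number from compound 1 to compound 4 (0.08 log units; within the scatter)), which shows no readable difference between 6-methoxypyridin-3-yl and 4-methoxyphenyl.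

Nothing shown gives a cause for these numbers. From the compounds shown here alone, whether a longer chain, or an amine at the end of this chain, would move the number beyond the scatter remains open.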